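A few compounds are considered here, and "the series" means these few. Any claim that something is new, unique, unknown or untested is made for them only; others in the source may bear on it.

Measured so far in a functional assay on HT-22 cells (Mus musculus), read by MTT assay; on this read-out lower numbers stand for higher toxicity in this test and higher numbers for lower toxicity in this test:
compound 1 `CC(C)CNC1Oc2ccc(C(=O)c3ccccc3)c(O)c2NC1(C)C` gives 45 uM.
Compound 3 `CC(C)CNC1Oc2ccc(C(=O)c3ccccc3)c(O)c2NC1c1ccccc1` gives 108 uM.
Compound 2 `COC(CNC1Oc2ccc(C(=O)c3ccccc3)c(O)c2NC1c1ccccc1)OC` reaches only the assay limit, > 250 uM.

Of the two numbers, compound 1 gives the lower and compound 3 the higher. Among the compounds with values here, the one step measured, an at least 2.3-fold lower number from compound 2 to compound 3 (0.36 log units; beyond the scatter), starts from a limit of > 250 uM in this assay, at which 1 of the 3 values shown sits, and changes the amine substituent only. Compound 4 `CC1(C)Nc2c(ccc(C(=O)c3ccccc3)c2O)OC1O` is not yet measured; it differs from compound 1 by hydroxy in place of isobutylamino on a saturated ring carbon. Within the data shown here, no measured step removes the amine, so the step in this assay is expected to stay within the scatter, direction open. For compound 4 the estimate is 50 uM, range 20 uM to 150 uM, meaning an expected step of a 1.1-fold higher number from compound 1 to compound 4 (0.05 log units; within the scatter).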

Compound 4, half-maximal toxic concentration: 48 uM
Beside the measured number, compound 4's estimate is 1.0-fold (0.02 log units) above it; measured number inside the range.
By their numbers in this assay, from the lowest: compounds 1 and 4 (each within the scatter of the next); then compound 3. At a limit, above all of these: compound 2.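

In this assay, hydroxy in place of isobutylamino on the saturated ring carbon next to the ring oxygen gives a 1.1-fold higher number from compound 1 to compound 4 (0.03 log units; within the scatter). Within the data shown here, the only earlier step altered the group on the amine nitrogen, whereas this one removes the whole isobutylamino group, and on the core of compound 1 the read-out holds with 1 heavy atom at this carbon instead of 5. Nothing at hand gives a reason for this outcome.

Going by these compounds, whether hydroxy reads the same on the core of compound 3 stays open. So does what a primary amine, a methoxy group or a carboxylic acid would give at this ring carbon.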